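Removing the hexyl tail from a macrolide side chain

The compounds below may be only part of what the source reports. "The series", "measured", "known", "first", "only" and "open" are said of these compounds alone.

This account concerns three macrolide derivatives measured in a physicochemical assay for lipophilicity, read by HPLC, measured as chromatographic lipophilicity, at pH 7.4 (on this read-out lower numbers stand for lower lipophilicity and higher numbers for higher lipophilicity), and a fourth whose value is to be estimated from them. Compound 1 `CCCCCCCC(=O)NCCCN(C)[C@H]1C[C@@H](C)O[C@@H](O[C@@H]2[C@@H](C)[C@H](O[C@H]3C[C@@](C)(OC)[C@@H](O)[C@H](C)O3)[C@@H](C)C(=O)O[C@H](CC)[C@@](C)(O)[C@H](O)[C@@H](C)C(=O)[C@H](C)C[C@@]2(C)OC)[C@@H]1O` carries a heptylcarbonyl amide on its side chain and gives 6.44, the highest of the three numbers. Compound 3 `CCCCCCCC(=O)NCCCO[C@@H]1[C@@H](C)C(=O)[C@H](C)C[C@@](C)(OC)[C@H](O[C@@H]2O[C@H](C)C[C@H](N(C)C)[C@H]2O)[C@@H](C)[C@H](O[C@H]2C[C@@](C)(OC)[C@@H](O)[C@H](C)O2)[C@@H](C)C(=O)O[C@H](CC)[C@@]1(C)O` carries the same heptylcarbonyl amide on a different core and gives 5.07. Compound 2 `CC[C@H]1OC(=O)[C@H](C)[C@@H](O[C@H]2C[C@@](C)(OC)[C@@H](O)[C@H](C)O2)[C@H](C)[C@@H](O[C@@H]2O[C@H](C)C[C@H](N(C)C)[C@H]2O)[C@](C)(OC)C[C@@H](C)C(=O)[C@H](C)[C@@H](OCCCNC(C)=O)[C@]1(C)O` is the acetamido counterpart of compound 3; in this assay compound 2 gives 2.72. The difference between the core of compound 1 and the core of compound 3 is not broken down here.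

The step from compound 3 to compound 2, (hydrogen in place of hexyl on a saturated chain carbon bound to a carbonyl carbon), is measured as a number 2.35 log units lower from compound 3 to compound 2 (beyond the scatter). Compound 4 `CC[C@H]1OC(=O)[C@H](C)[C@@H](O[C@H]2C[C@@](C)(OC)[C@@H](O)[C@H](C)O2)[C@H](C)[C@@H](O[C@@H]2O[C@H](C)C[C@H](N(C)CCCNC(C)=O)[C@H]2O)[C@](C)(OC)C[C@@H](C)C(=O)[C@H](C)[C@@H](O)[C@]1(C)O` stands to compound 1 as compound 2 stands to compound 3: the change is hydrogen in place of hexyl on a saturated chain carbon bound to a carbonyl carbon, the same change, at the same place. Because compound 3 to compound 2 gave a number 2.35 log units lower from compound 3 to compound 2 (beyond the scatter), a step of about the same size is expected from compound 1 to compound 4, and the estimate implies a number 2.34 log units lower from compound 1 to compound 4 (beyond the scatter). That expectation rests on one measured pair only, so some spread is allowed around it. Compound 4 is therefore estimated at 4.1 in this assay, with a plausible range from 3.4 to 4.8.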

Compound 4, distribution coefficient: 3.08
The estimate for compound 4 lay 1.02 log units above the measured number; the whole stated range lies above it.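

In this assay, hydrogen in place of hexyl on a saturated chain carbon bound to a carbonyl carbon gives a number 3.36 log units lower from compound 1 to compound 4 (beyond the scatter) on the core of compound 1 and, on the core of compound 3, gives a number 2.35 log units lower from compound 3 to compound 2 (beyond the scatter) in the same direction, so the number fell by a large step beyond the scatter in both pairs. The direction of the change therefore carried from one core to the other in these two pairs, but its size did not carry over unchanged: the step on the core of compound 1 is the larger of the two printed steps, and the step measured on one core was not a close guide to the step on the other. Two pairs set no rule for any further core, and nothing available accounts for the difference in size between the two steps.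

The compounds shown leave open whether a butyl group in place of hexyl would give a smaller step on either core, and whether the two cores would again differ in step size with that shorter chain. They also leave open what an amine or a carboxylic acid in place of hexyl at the same place would do to the number on each core.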